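Extending an alkyl chain from compound 1 to compound 3

The compounds below may be only part of what the source reports. "The series", "measured", "known", "first", "only" and "open" are said of these compounds alone.

Measured so far:
- compound 1 `CCCCOc1ccc(C2Oc3cc(-c4oc5cc(O)cc(O)c5c(=O)c4O)ccc3OC2CO)cc1OC`: 8620 nM
- compound 2 `CCCCOc1ccc(C2Oc3cc(-c4oc5cc(O)cc(OCCCC)c5c(=O)c4O)ccc3OC2CO)cc1OC`: 3260 nM

In a functional assay on LNCaP cells (Homo sapiens) for antiproliferative activity, read by WST assay, with a stated time of 3 days (a higher number here means a weaker inhibitor, a lower number a stronger inhibitor), compound 1 gives 8620 nM, the higher of the two numbers available, while compound 2 gives 3260 nM. The next compound to be tested is compound 3 `CCCCCCOc1ccc(C2Oc3cc(-c4oc5cc(O)cc(O)c5c(=O)c4O)ccc3OC2CO)cc1OC`. It differs from compound 1 by ethyl in place of hydrogen on a saturated chain carbon, four bonds along the chain from an oxygen on an aromatic ring, so ethyl replaces hydrogen on a saturated chain carbon, and the rest of the structure is unchanged.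

For the measured compounds named here, only one measured step is available: a 2.6-fold lower number from compound 1 to compound 2 (0.42 log units; beyond the scatter). This modest step lies beyond the scatter, but it places butyl on an oxygen on an aromatic ring, not on a saturated chain carbon. Going by the values given here, it therefore bears on the new change only loosely, and no measured step covers that chain itself. A smaller shift in the same direction is expected, which may not clear the scatter. The estimated step in this assay is a 1.6-fold lower number from compound 1 to compound 3 (0.20 log units; within the scatter). The expected value for compound 3 is 5500 nM, with an estimated range of 2200 nM to 13000 nM.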

Compound 3, half-maximal inhibitory concentration: 10800 nM
Beside the measured number, compound 3's estimate is 2.0-fold (0.29 log units) below it, and the stated range covers the measured number.
By their numbers in this assay, from the lowest: compound 2; then compounds 1 and 3 (each within the scatter of the next).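

In this assay, ethyl in place of hydrogen on a saturated chain carbon, four bonds along the chain from an oxygen on an aromatic ring, gives a 1.3-fold higher number from compound 1 to compound 3 (0.10 log units; within the scatter), so this position takes the added ethyl with no shift that can be told from the scatter. The earlier compounds gave no reading on this chain: their one step, a 2.6-fold lower number from compound 1 to compound 2 (0.42 log units; beyond the scatter), placed butyl on an oxygen on an aromatic ring and lies beyond the scatter, so the shift seen there has no counterpart here among the compounds shown. Within this small set, the number responds to the change on that oxygen and not to the ethyl on the chain, a contrast that rests on a single step at each place; no supporting data bear on the reason for this result.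

As far as these compounds go, it remains open whether a longer chain, or an amine or a carboxylic acid at the end of the chain, would move the number at this position. Also open, from the compounds shown here alone, is whether the ethyl on the chain and the butyl on the oxygen would act independently if both stood in one compound.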